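The compounds below may be only part of what the source reports. "The series", "measured", "known", "first", "only" and "open" are said of these compounds alone.

Working notes on the series, read in a functional assay on A549 cells (Homo sapiens) for cytotoxicity; on this read-out higher numbers stand for an effect only at larger amounts of compound and lower numbers for an effect already at smaller amounts. Compound 1 `c1ccc(COc2cc(-c3ccccc3)nc3ccccc23)cc1` carries benzyl on an oxygen on an aromatic ring, and compound 1 gives > 10 ug/mL, which is a limit and not a number. Compound 2 `CC(C)Oc1cc(-c2ccccc2)nc2ccccc12` gives > 10 ug/mL, again a limit. Compound 3 `Oc1cc(-c2ccccc2)nc2c(O)cccc12` gives > 10 ug/mL, also a limit. Compound 2 therefore has no number of its own, and neither do the two compounds shown with it: the limit of > 10 ug/mL in this assay, at which 3 of the 3 values shown sit.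

Compound 4 `CC(C)COc1cc(-c2ccccc2)nc2ccccc12` has isobutyl in place of isopropyl on an oxygen on an aromatic ring, so the isopropoxy of compound 2 becomes isobutoxy: isobutyl in place of isopropyl on an oxygen on an aromatic ring.

Going by the values given here, only one measured step bears on this change, at the same oxygen: a step that the two limits leave unreadable from compound 1 to compound 2. It gives no size to carry over, and no direction can be taken from it. No step beyond the scatter is expected in this assay, and compound 4 is expected to stay at the same limit because of the limit of > 10 ug/mL in this assay, at which 3 of the 3 values shown sit. The expected step, with no direction supported by the data, is a step that the limit leaves unreadable from compound 2 to compound 4. For compound 4 the estimated value is 15 ug/mL, with an expected range of 6 ug/mL to 40 ug/mL.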

Compound 4, half-maximal effective concentration: > 10 ug/mL
Compound 4: a limit, no number (the forecaster's own chance of this, stated with the estimate: 85%); the middle value does not contradict the limit.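

No new step can be read: the comparisons of compound 4 with compound 2 and with compound 1 have only limits on both sides, so they carry no size: the limit of > 10 ug/mL in this assay, at which 4 of the 4 values shown sit.

The compounds shown leave open at what concentration any of them acts in this assay, and whether the group on the oxygen changes that concentration at all.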